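This account rests on a few compounds, and the source may have more. Where it says the series, first, only, none or still open, it means among the compounds named here.

Cytotoxicity notes on the series. Compound 1 `CC(C)C[C@H](NC(=O)OCC1CC2CCCC(C2)C1)C(=O)N[C@H](C=O)C[C@H]1CCNC1=O` sits at the limit of a functional assay on Huh-7 cells (Homo sapiens) for cytotoxicity (a lower number here means that less compound is tolerated, a higher number that more compound is tolerated), rather than at a number, with > 100000 nM; > 100000 nM (2 entries) in this assay. Compound 2 `CC(C)C[C@H](NC(=O)OCC1CC2C=CCC(C2)C1)C(=O)N[C@H](C=O)C[C@H]1CCNC1=O` likewise gives only the limit > 100000 nM; > 100000 nM (2 entries) in this assay. Compound 3 `CC(C)C[C@H](NC(=O)OCC1CC2C=CC1C2)C(=O)N[C@H](C=O)C[C@H]1CCNC1=O` also reaches only the limit, > 100000 nM in this assay, so no single number places it; it stands on the line the limit of > 100000 nM in this assay, at which 1 of the 3 values shown sits, together with the other two. Among the compounds with values here, no step between measured compounds can be drawn. Compound 4 `CC(C)C[C@H](NC(=O)OCC1CC2CCC1C2)C(=O)N[C@H](C=O)C[C@H]1CCNC1=O` differs from compound 3 by a group of 7 heavy atoms (7 carbon; 2 five-membered non-aromatic rings of carbon only) in place of a group of 7 heavy atoms (7 carbon; 2 five-membered non-aromatic rings of carbon only), on a saturated chain carbon bound to an oxygen next to a carbonyl group. With every measured compound at the limit, the expected step from compound 3 to compound 4 is a step that the limit leaves unreadable from compound 3 to compound 4, none beyond the scatter. Compound 4 is estimated at 150000 nM, between 70000 nM and 300000 nM, most likely reported again as a limit.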

Compound 4, half-maximal cytotoxic concentration: > 100000 nM
Compound 4: a limit, no number; the forecaster's own chance of this, stated with the estimate: 85%; the middle value does not contradict the limit.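

Within the data shown here, compound 3 and compound 4 both give only a limit in this assay, so no step between them can be read: the limit of > 100000 nM in this assay, at which 2 of the 4 values shown sit. The compounds shown leave open at what concentration any of them becomes cytotoxic, and whether their differing groups change that concentration.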